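The source may hold more compounds than are shown below. What is called first, only, known or untested is meant among the compounds shown, and "the series" means these compounds.

In a functional assay on DU-145 cells (Homo sapiens) for inhibition, read by WST assay, with a stated time of 3 days (a lower number here means a stronger inhibitor, a higher number a weaker inhibitor), three compounds have been measured:

- compound 1 `Cn1ccnc1/C=C/C(=O)/C=C/c1coc2ccccc2c1=O`: 4500 nM
- compound 2 `CCCn1ccnc1/C=C/C(=O)/C=C/c1coc2ccccc2c1=O`: 4600 nM
- compound 3 `CC(C)n1ccnc1/C=C/C(=O)/C=C/c1coc2ccccc2c1=O`: 3300 nM

These three differ only in the group on the aromatic nitrogen, and compound 3 cannot be separated from the other two. Its steps are a 1.4-fold lower number from compound 1 to compound 3 (0.13 log units; within the scatter) and a 1.4-fold lower number from compound 2 to compound 3 (0.14 log units; within the scatter), both within the scatter. The remaining step, a 1.0-fold higher number from compound 1 to compound 2 (0.01 log units; within the scatter), is also within the scatter.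

Compound 4 `CCCC(C)n1ccnc1/C=C/C(=O)/C=C/c1coc2ccccc2c1=O` extends this series. Its difference from compound 3 is ethyl in place of hydrogen on a saturated chain carbon, two bonds along the chain from an aromatic nitrogen, so that isopropyl becomes 1-methylbutyl, with ethyl in place of hydrogen on a saturated chain carbon, two bonds along the chain from an aromatic nitrogen. Among the measured compounds shown here, no measured compound carries a group this large, so the expectation is an extrapolation from these three small steps. No change beyond the scatter is expected in this assay, and no direction can be favoured. The expected step is a 1.1-fold higher number from compound 3 to compound 4 (0.03 log units; within the scatter). The estimate for compound 4 is 3500 nM, with an expected range of 1700 nM to 7000 nM.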

Compound 4, half-maximal inhibitory concentration: 1400 nM
Compound 4: middle estimate off by 2.5-fold (0.40 log units), on the high side, outside the stated range (below it).
By their numbers in this assay, from the lowest: compound 4; then compounds 3, 1 and 2 (each within the scatter of the next).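

In this assay, the group on the aromatic nitrogen now gives a step beyond the scatter, which none of the steps among compounds 1, 2 and 3 did. Going to 1-methylbutyl gives a 2.4-fold lower number from compound 3 to compound 4 (0.37 log units; beyond the scatter), and the longer comparisons give a 3.3-fold lower number from compound 2 to compound 4 (0.52 log units; beyond the scatter) and a 3.2-fold lower number from compound 1 to compound 4 (0.51 log units; beyond the scatter). The same ethyl-for-hydrogen change stayed within the scatter on the smaller group, yet the two instances cannot be told apart, so no dependence on the starting group is established: the same change on two cores in this assay, a 1.0-fold higher number (0.01 log units; within the scatter) from compound 1 to compound 2 and a 2.4-fold lower number (0.37 log units; beyond the scatter) from compound 3 to compound 4, 2.4-fold (0.38 log units) apart, within the scatter of two such steps.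

Compound 4 alone carries a group of this size, so a single result supports the lower number. On these data alone, it remains open whether the branched 1-methylbutyl is needed, as an unbranched pentyl would show, and whether a larger group such as cyclohexyl or a chain ending in an amine would go further.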